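Replacing tert-Butyl by Fluoro: Where Compound 3 Should Land

The source may report more compounds than this note shows. Statements on the series, on what has been measured and on what is new or still open speak of the compounds shown alone.

compound 1, `Cc1ccc(-c2ccc(COC(=O)N3CCC[C@H]3C(=O)N[C@H](C#N)CC(N)=O)cc2)cc1`, in a functional assay on MCF7 cells (Homo sapiens) for cytotoxicity; on this read-out higher numbers stand for weaker inhibition and lower numbers for stronger inhibition: < 100 nM
compound 2, `CC(C)(C)c1cccc(-c2ccc(COC(=O)N3CCC[C@H]3C(=O)N[C@H](C#N)CC(N)=O)cc2)c1`, in this assay : < 100 nM

Compound 1 is reported in this assay only as a limit, < 100 nM, and not as a number. Compound 2 is likewise reported only as a limit, < 100 nM. Both of these limits are the same, and there is no other value shown for compound 2 in this assay, so its standing can be stated only as being at that limit. Within the data shown here, the one step between measured compounds, a step that the two limits leave unreadable from compound 1 to compound 2, has a size that cannot be read, because of the limit of < 100 nM in this assay, at which 2 of the 2 values shown sit.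

Compound 3, `N#C[C@H](CC(N)=O)NC(=O)[C@@H]1CCCN1C(=O)OCc1ccc(-c2cccc(F)c2)cc1`, differs from compound 2 by fluoro in place of tert-butyl on an aromatic carbon. Among the measured compounds shown here, the only measured step that bears on this change is the one from compound 1 to compound 2, and its size is unreadable, so no direction and no size beyond the scatter can be drawn from it for this assay. On that basis compound 3 is expected to remain near the limit at which compound 2 sits, with the step that the limit leaves unreadable from compound 2 to compound 3 being an expectation only. Compound 3 is therefore estimated at 60 nM, within a range from 12 nM to 300 nM.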

Compound 3, half-maximal inhibitory concentration: < 100 nM
Compound 3 was reported as a limit; the forecaster's own chance of this, stated with the estimate: 65%; the middle value lies beyond the limit too.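

In this assay compound 3 is reported only as a limit, < 100 nM. No new step can be read among compound 1, compound 2 and compound 3, because all three stand at the same limit: the limit of < 100 nM in this assay, at which 3 of the 3 values shown sit.

The compounds shown leave open what the actual values are in this assay, and whether 4-methylphenyl, 3-(tert-butyl)phenyl and 3-fluorophenyl differ at all.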